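From piperidin-1-yl to propylamino on a thiocarbonyl carbon

The source may hold more compounds than are shown below. What is called first, only, known or untested is meant among the compounds shown, and "the series" means these compounds.

In a functional assay on SGC-7901 cells (Homo sapiens) for cytotoxicity, read by MTT assay, with a stated time of 72 h (a higher number here means a weaker inhibitor, a lower number a stronger inhibitor), compound 3 `Oc1ccc(C2C/C(=N\NC(=S)N3CCCCC3)c3ccc(O)cc3O2)cc1` gives 40000 nM and stands within the scatter of both its measured relatives. Compound 1 `CC(C)NC(=S)N/N=C1\CC(c2ccc(O)cc2)Oc2cc(O)ccc21` gives 35200 nM here, and compound 2 `CCCCNC(=S)N/N=C1\CC(c2ccc(O)cc2)Oc2cc(O)ccc21` gives 50800 nM here. Compound 4 `CCCNC(=S)N/N=C1\CC(c2ccc(O)cc2)Oc2cc(O)ccc21` remains unmeasured. It carries propylamino in place of piperidin-1-yl on a thiocarbonyl carbon. Going by the values given here, three measured steps bear on this change: a 1.1-fold higher number from compound 1 to compound 3 (0.06 log units; within the scatter) and a 1.3-fold lower number from compound 2 to compound 3 (0.10 log units; within the scatter) exchange an amino group for piperidin-1-yl on that carbon, while a 1.4-fold higher number from compound 1 to compound 2 (0.16 log units; within the scatter) changes only the chain, and all three lie within the scatter. No step beyond the scatter is therefore expected, so the estimated step is a 1.1-fold higher number from compound 3 to compound 4 (0.02 log units; within the scatter) only. In this assay the expected value for compound 4 is 42000 nM (estimated range 26000 nM to 68000 nM).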

Compound 4, half-maximal inhibitory concentration: 31200 nM
The estimate for compound 4 lay 1.3-fold (0.13 log units) above the measured number; low and high end bracket the measured number.
By their numbers in this assay, from the lowest: compounds 4, 1, 3 and 2 (each within the scatter of the next).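

In this assay, propylamino in place of piperidin-1-yl on a thiocarbonyl carbon gives a 1.3-fold lower number from compound 3 to compound 4 (0.11 log units; within the scatter), so exchanging the six-membered ring for an open chain with a hydrogen-bond donor produces no step beyond the scatter. The chain steps agree, with a 1.6-fold lower number from compound 2 to compound 4 (0.21 log units; within the scatter) and a 1.1-fold lower number from compound 1 to compound 4 (0.05 log units; within the scatter), so propylamino does not separate from butylamino or isopropylamino here. No measurement available here explains why these numbers stay together. The compounds shown leave open whether phenylamino, morpholin-4-yl or a longer chain on the thiocarbonyl carbon would give a step beyond the scatter. They also leave open whether any change to the shared core would do so.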